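The source may report more compounds than this note shows. Statements on the series, on what has been measured and on what is new or still open speak of the compounds shown alone.

Measured compounds:
Compound 1 `COc1ccc2c(/C=C/C(=O)c3cc(N)c(OC)c(OC)c3)cn(C)c2c1`: 455 nM
Compound 2 `COc1cc(C(=O)/C=C/c2cn(C)c3ccccc23)cc(N)c1OC`: 605 nM
Compound 3 `COc1ccc2c(/C=C/C(=O)c3cc(OC)c(OC)c([N+](=O)[O-])c3)cn(C)c2c1`: 753 nM

In a functional assay on HCT-8 cells (Homo sapiens) for antiproliferative activity, read by MTT assay, with a stated time of 48 h (a higher number here means a weaker inhibitor, a lower number a stronger inhibitor), compound 1 gives the lowest of these three numbers, yet both steps away from it, a 1.3-fold higher number from compound 1 to compound 2 (0.12 log units; within the scatter) and a 1.7-fold higher number from compound 1 to compound 3 (0.22 log units; within the scatter), stay within the usual scatter, so the three compounds cannot be told apart. Compound 4 `COc1ccc2c(/C=C/C(=O)c3cc(N)c(OC)c(OC)c3)c[nH]c2c1` differs from compound 1 in one place: hydrogen in place of methyl on an aromatic nitrogen. Neither measured step touches this position on the shared core; both changed groups on the other aromatic ring and neither moved the number beyond the scatter. Among the compounds with values here, no measured step bears directly on this change, so no step beyond the scatter is expected. Compound 4 is therefore expected to give about 500 nM, within a range from 200 nM to 1300 nM. That expectation means a 1.1-fold higher number from compound 1 to compound 4 (0.04 log units; within the scatter).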

Compound 4, half-maximal inhibitory concentration: 368 nM
For compound 4 the middle estimate is 1.4-fold (0.13 log units) above the measured one; the range from low to high includes it.
By their numbers in this assay, from the lowest: compounds 4, 1, 2 and 3 (each within the scatter of the next, the first and the last beyond it).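

In this assay, within the data shown here, hydrogen in place of methyl on the aromatic nitrogen gives a 1.2-fold lower number from compound 1 to compound 4 (0.09 log units; within the scatter), the first step to touch this position. In this one pair, then, the methyl is not needed to keep the number in the range of compound 1. Nothing available explains why so small a step results.

On these data alone, only hydrogen and methyl appear on this nitrogen, so a longer chain such as butyl, or a benzyl group, remains open. Whether either would leave the number within the scatter cannot be told.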